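This account rests on a few compounds, and the source may have more. Where it says the series, first, only, none or still open, it means among the compounds named here.

For the measured compounds named here, in a functional assay on OVCAR-3 cells (Homo sapiens) for inhibition, read by MTT assay, with a stated time of 24 h (on this read-out higher numbers stand for weaker inhibition and lower numbers for stronger inhibition), compound 1 `CC1(C)[C@H]2CC[C@]1(C)N(Cc1cn(-c3ccccc3Cl)nn1)C(=O)C2` gives 40 nM and compound 2 `COc1cccc(-n2cc(CN3C(=O)C[C@@H]4CC[C@@]3(C)C4(C)C)nn2)c1` gives 280 nM, the higher of the two numbers so far. Compound 3 `Cc1cccc(-n2cc(CN3C(=O)C[C@@H]4CC[C@@]3(C)C4(C)C)nn2)c1` keeps the shared core and differs from compound 2 at one place: methyl in place of methoxy on an aromatic carbon, meta to a large group (methyl in place of methoxy on an aromatic carbon). Going by the values given here, only one measured step bears on this, a 7.0-fold higher number from compound 1 to compound 2 (0.85 log units; beyond the scatter), with 3-methoxyphenyl in place of 2-chlorophenyl on an aromatic nitrogen. Among the compounds with values here, that step exchanges the whole aromatic substituent, and no measured pair isolates methoxy against methyl. A smaller move than that step is therefore expected, most likely toward a slightly lower number, though the direction is not firm. The estimated step is a 1.4-fold lower number from compound 2 to compound 3 (0.15 log units; within the scatter). The expected value for compound 3 is 200 nM, with an estimated range of 60 nM to 600 nM.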

Compound 3, half-maximal inhibitory concentration: 160 nM
For compound 3 the middle estimate is 1.3-fold (0.10 log units) above the measured one; the measured number falls inside the stated range.
By their numbers in this assay, from the lowest: compound 1; then compounds 3 and 2 (each within the scatter of the next).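

Working notes on the series, in this assay: the exchange of methoxy for methyl on this aromatic carbon, meta to a large group, stays within the scatter (a 1.8-fold lower number from compound 2 to compound 3 (0.24 log units; within the scatter)), so the two groups are not told apart here. The earlier step from compound 1 to compound 2 exchanged the whole aromatic substituent, whereas this pair isolates the methoxy and shows that its oxygen makes no difference beyond the scatter. Compound 1 remains clearly apart from the 3-methylphenyl analogue as well (a 4.0-fold higher number from compound 1 to compound 3 (0.60 log units; beyond the scatter)), so the gap seen earlier does not depend on the methoxy.

From the compounds shown here alone, both steps from compound 1 change the substituent and its place together, so it remains open which of the two carries the gap, and how an amine or a carboxylic acid would read at this position. No measurement at hand accounts for these numbers.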